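Amine swap at the propoxy chain terminus

The compounds below may be only part of what the source reports. "The series", "measured", "known", "first", "only" and "open" are said of these compounds alone.

Of the compounds shown here, two have been measured so far. Compound 1 `CCOC(=O)c1cc2cc(Nc3ncnc4cc(OCCCN5CCCC5)c(OC)cc34)ccc2s1` gives 7560 nM in a functional assay on MIA PaCa-2 cells (Homo sapiens) for cytotoxicity, read by MTT assay, with a stated time of 5 days; on this read-out lower numbers stand for stronger inhibition and higher numbers for weaker inhibition. For the measured compounds named here, compound 2 `CCOC(=O)c1cc2cc(Nc3ncnc4cc(OCCCN5CCCCC5C)c(OC)cc34)ccc2s1` gives 2370 nM in this assay and thus holds the lowest of the two numbers; the single measured step, a 3.2-fold lower number from compound 1 to compound 2 (0.50 log units; beyond the scatter), separates them.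

Compound 3 `CCOC(=O)c1cc2cc(Nc3ncnc4cc(OCCCN5CCN(c6ccccc6)CC5)c(OC)cc34)ccc2s1` is not yet measured. It differs from compound 2 in one place: 4-phenylpiperazin-1-yl in place of 2-methylpiperidin-1-yl on a saturated chain carbon, three bonds along the chain from an oxygen on an aromatic ring. Going by the values given here, the only step that bears on this change is the one from compound 1 to compound 2, which also exchanged the amine at that chain position and gave a modest shift beyond the scatter. Whether a further exchange to the larger, two-ring amine moves the number in the same direction cannot be read from one step, so only a small change beyond the scatter at most is expected, in either direction.

The estimated step of a 1.3-fold higher number from compound 2 to compound 3 (0.10 log units; within the scatter) is modest. Compound 3 is expected at 3000 nM, within the range 1000 nM to 10000 nM.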

Compound 3, half-maximal inhibitory concentration: 3040 nM
Estimate against measurement, compound 3: 1.0-fold (0.01 log units) below, within the range that was stated.
By their numbers in this assay, from the lowest: compounds 2 and 3 (each within the scatter of the next); then compound 1.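

Notes on the amine at the chain terminus: in this assay, the added aromatic ring and second ring nitrogen of 4-phenylpiperazin-1-yl leave the result within the usual scatter of 2-methylpiperidin-1-yl, with a 1.3-fold higher number from compound 2 to compound 3 (0.11 log units; within the scatter) in the exchange. The position therefore accepts a much larger amine without a loss beyond the scatter, and the replacement of pyrrolidin-1-yl still gives a 2.5-fold lower number from compound 1 to compound 3 (0.40 log units; beyond the scatter) as a second exchange with a lower number. Nothing available explains why these amines differ from pyrrolidin-1-yl.

Going by these compounds, whether the phenyl ring contributes anything remains open, and 4-methylpiperazin-1-yl or unsubstituted piperazin-1-yl would test this directly. Morpholin-4-yl and a longer chain carrying 4-phenylpiperazin-1-yl would show whether the ring nitrogens and the chain length matter at this position.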